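Swapping the urea aryl group on a pyrazole series

The source may hold more compounds than are shown below. What is called first, only, known or untested is meant among the compounds shown, and "the series" means these compounds.

Measured compounds:
- compound 1 `O=C(Nc1cccc(-n2cc(-c3ccncc3)c(-c3ccc(Cl)c(O)c3)n2)c1)Nc1cccc(C(F)(F)F)c1`: 1460 nM
- compound 2 `COc1cc(-c2nn(-c3cccc(NC(=O)Nc4cc(C(F)(F)F)cc(C(F)(F)F)c4)c3)cc2-c2ccncc2)ccc1Cl`: 623 nM

In a functional assay on NCI-H522 cells (Homo sapiens) for inhibition, read by sulforhodamine B assay, with a stated time of 48 h (a higher number here means a weaker inhibitor of growth, a lower number a stronger inhibitor of growth), compound 1 gives 1460 nM, the higher of the two numbers; compound 2 gives 623 nM, a gap beyond the usual scatter, but these two differ in more than one place, so no single change can be credited. Compound 3 `O=C(Nc1cccc(-n2cc(-c3ccncc3)c(-c3ccc(Cl)c(O)c3)n2)c1)Nc1ccc(Cl)c(Cl)c1` carries 3,4-dichlorophenyl in place of 3-(trifluoromethyl)phenyl on an amide-type nitrogen. Within the data shown here, no measured pair shows this change, so the expected step from compound 1 to compound 3 is uncertain and small, a 1.5-fold lower number from compound 1 to compound 3 (0.16 log units; within the scatter), with no clear direction beyond the scatter. Compound 3 is estimated at 1000 nM, between 300 nM and 3500 nM.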

Compound 3, concentration for 50% growth inhibition: 1190 nM
Compound 3: the middle estimate sits 1.2-fold (0.08 log units) below what was measured; the measured number falls inside the stated range.
By their numbers in this assay, from the lowest: compounds 2, 3 and 1 (each within the scatter of the next, the first and the last beyond it).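

In this assay, among these compounds, 3,4-dichlorophenyl in place of 3-(trifluoromethyl)phenyl on an amide-type nitrogen gives a 1.2-fold lower number from compound 1 to compound 3 (0.09 log units; within the scatter), the first comparison here in which only one place differs. At this position, these two aryl groups cannot be told apart. Nothing available explains this result.

Still open, going by these compounds, is whether a different kind of group at this position, such as a carboxylic acid or an amine on the phenyl ring, would shift the number beyond the scatter. On these data alone, whether the shared core's other groups matter also remains open.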